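Methyl for propyl on the core of compound 2

The source may hold more compounds than are shown below. What is called first, only, known or untested is meant among the compounds shown, and "the series" means these compounds.

Compound 2, `CCCn1c(=O)c2nc(-c3ccc(C#N)cc3)[nH]c2n(CCC)c1=O`, has been measured in an assay on Cortex for displacement of a labelled ligand from adenosine receptor A1 (Rattus norvegicus) (a higher number here means a weaker inhibitor, a lower number a stronger inhibitor), and gives 4.48 nM. Compound 1, `CCCn1c(=O)c2nc(-c3ccccc3)[nH]c2n(C)c1=O`, gives in this assay 6.96 nM. Of these two numbers compound 2 has the lower one, but the gap to compound 1 lies within the scatter, so the two values cannot be told apart. The next compound, compound 3, `CCCn1c(=O)c2nc(-c3ccc(C#N)cc3)[nH]c2n(C)c1=O`, has not yet been measured in this assay. It differs from compound 2 by hydrogen in place of ethyl on a saturated chain carbon bound to an aromatic nitrogen; read one bond further out, the change is propyl to methyl. For the measured compounds named here, no measured pair shows this change on its own, so its effect in this assay has no direct precedent in these data. The expected step, a 1.2-fold higher number from compound 2 to compound 3 (0.09 log units; within the scatter), stays inside the scatter with no clear direction. Compound 3 is accordingly estimated to give about 5.5 nM in this assay, with a range from 2.5 nM to 14 nM.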

Compound 3, inhibition constant: 5.95 nM
The estimate for compound 3 lay 1.1-fold (0.03 log units) below the measured number; low and high end bracket the measured number.
By their numbers in this assay, from the lowest: compounds 2, 3 and 1 (each within the scatter of the next).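

In this assay, propyl to methyl on a saturated chain carbon bound to an aromatic nitrogen now has a direct reading, a 1.3-fold higher number from compound 2 to compound 3 (0.12 log units; within the scatter), so with the nitrile present on the aryl group this shortening of the chain gives no difference that can be told from the scatter. For the compounds shown here, compound 3 also gives the first single-place reading of cyano in place of hydrogen on an aromatic carbon, a 1.2-fold lower number from compound 1 to compound 3 (0.07 log units; within the scatter), which means that with methyl on the core this exchange likewise cannot be told from the scatter. Neither step can be tied to an explanation, as the data hold nothing that bears on these results.

From the compounds shown here alone, each change has been read on one background only, so whether the nitrile exchange gives the same reading with propyl on the core remains open. Also open, going by these compounds, is whether a longer chain such as hexyl or a benzyl group on that nitrogen, or an amine or a carboxylic acid in place of the nitrile, would move the number beyond the scatter.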